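This account rests on a few compounds, and the source may have more. Where it says the series, first, only, none or still open, it means among the compounds named here.

Compound 1 `COc1cc(C)ccc1S(=O)(=O)NC1=NCCN1C(=S)SN1CCn2c1nsc2=S` is the starting point. In a functional assay on KYSE-510 cells (Homo sapiens) for antiproliferative activity, read by crystal violet staining, with a stated time of 96 h (on this read-out lower numbers stand for stronger inhibition of growth and higher numbers for weaker inhibition of growth), compound 1 gives only a limit of the assay, >= 20000 nM. Two measured relatives share its core. Compound 2 `CC(=O)Nc1ccc(S(=O)(=O)NC2=NCCN2C(=S)SN2CCn3c2nsc3=S)cc1` likewise reaches only a limit in this assay, >= 20000 nM. Compound 3 `O=S(=O)(NC1=NCCN1C(=S)SN1CCn2c1nsc2=S)c1ccc2ccccc2c1` also stops at a limit in this assay, >= 20000 nM. Accordingly the steps among these three cannot be read: a step that the two limits leave unreadable from compound 1 to compound 2, a step that the two limits leave unreadable from compound 1 to compound 3 and a step that the two limits leave unreadable from compound 2 to compound 3 all remain of unknown size, because of the limit of >= 20000 nM in this assay, at which 3 of the 3 values shown sit. Compound 4 `O=S(=O)(NC1=NCCN1C(=S)SN1CCn2c1nsc2=S)c1cccc2ccccc12` is not yet measured; it differs from compound 1 as follows: naphthalen-1-yl in place of 2-methoxy-4-methylphenyl on a sulfonyl sulfur. For the measured compounds named here, the measured step that comes closest is the one to compound 3, where naphthalen-2-yl took the place of the same 2-methoxy-4-methylphenyl on the sulfonyl sulfur and yielded only a limit. No readable step exists to set a direction, so no change beyond the scatter in this assay can be foreseen, and a further limit is the likeliest outcome. Compound 4 is therefore expected to give 30000 nM, within 10000 nM to 100000 nM. The step from compound 1 to compound 4 that this expectation means is a step that the limit leaves unreadable from compound 1 to compound 4.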

Compound 4, concentration for 50% growth inhibition: >= 20000 nM
Compound 4 was reported as a limit (the forecaster's own chance of this, stated with the estimate: 85%); the middle value lies beyond the limit too.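

The steps from compound 1, compound 2 and compound 3 to compound 4 in this assay cannot be read, because each value is a limit: the limit of >= 20000 nM in this assay, at which 4 of the 4 values shown sit. The compounds shown leave open which group on the sulfonyl sulfur, if any, would give a readable value.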